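A Four-Membered Ring Takes the Place of Isopropyl

The source may hold more compounds than are shown below. What is called first, only, known or untested is meant among the compounds shown, and "the series" means these compounds.

Compound 1, `CC(C)c1noc(N2CCN(C(=O)[C@@H]3CCCN(S(=O)(=O)c4ccc(S(=O)(=O)C(C)C)cc4)C3)CC2)n1`, was tested in a functional assay on MIA PaCa-2 cells (Homo sapiens) for inhibition, read by MTT assay, with a stated time of 3 days; on this read-out lower numbers stand for stronger inhibition and higher numbers for weaker inhibition. In this assay compound 1 gives > 10000 nM, which is a limit of the assay rather than a number. Compound 2, `CCN(CC)C(=O)[C@@H]1CCCN(S(=O)(=O)c2ccc(S(=O)(=O)N(CC)CC)cc2)C1`, is the second measured member of the set. In this assay compound 2 gives > 10000 nM, again a limit and not a number. Compound 1 thus stands where every value shown so far stands: the limit of > 10000 nM in this assay, at which 2 of the 2 values shown sit. Among the measured compounds shown here, no step between the two measured compounds can be read; neither returns a number, so neither order nor change can be stated.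

Compound 3, `CC(C)c1noc(N2CCN(C(=O)[C@@H]3CCCN(S(=O)(=O)c4ccc(S(=O)(=O)C5CCC5)cc4)C3)CC2)n1`, has not yet been measured in this assay. It differs from compound 1 in a single place: cyclobutyl in place of isopropyl on a sulfonyl sulfur. For the measured compounds named here, no measured pair shows what this change does here, and the only evidence is the limit of > 10000 nM in this assay, at which 2 of the 2 values shown sit. The expected step is therefore none beyond the scatter, and the estimate means a step that the limit leaves unreadable from compound 1 to compound 3. Compound 3 is expected to give 15000 nM, with a range from 5000 nM to 50000 nM, and most likely only a limit will be reported.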

Compound 3, half-maximal inhibitory concentration: > 10000 nM
Compound 3 was reported as a limit (the forecaster's own chance of this, stated with the estimate: 85%); the middle value does not contradict the limit.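

No step can be read from compound 1 to compound 3, since each returns only a limit and not a number, so cyclobutyl in place of isopropyl on a sulfonyl sulfur has no measurable size here. The compounds shown leave open which change to the shared core, if any, would give a measurable value in this assay: the limit of > 10000 nM in this assay, at which 3 of the 3 values shown sit.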